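Chloro Substitution on Two Anilide-Type Lipoic Acid Derivatives

The source may report more compounds than this note shows. Statements on the series, on what has been measured and on what is new or still open speak of the compounds shown alone.

Measured compounds:
compound 1, `O=C(CCCCC1CCSS1)Nc1ccccn1`, 37.6%
compound 2, `O=C(CCCCC1CCSS1)Nc1ccc(Cl)cn1`, 48.5%
compound 3, `O=C(CCCCC(CCSC(=O)c1ccccc1)SC(=O)c1ccccc1)Nc1ccccc1`, "not active" (no number reported)

All three were tested in a functional assay on Bel-7402 cells (Homo sapiens) for inhibition, read by MTT assay, with a stated time of 24 h, tested at 100 ug/mL; on this read-out lower numbers stand for less inhibition of growth and higher numbers for more inhibition of growth at the one concentration tested. Compound 1 gives 37.6%, and compound 2, which carries chloro in place of hydrogen on an aromatic carbon, gives 48.5%; the step is a number 10.9 percentage points higher from compound 1 to compound 2 (beyond the scatter). Compound 3 is reported as "not active" (no number reported), with no number behind it. The difference between the core of compound 1 and the core of compound 3 is not broken down here.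

Compound 4, `O=C(CCCCC(CCSC(=O)c1ccccc1)SC(=O)c1ccccc1)Nc1ccccc1Cl`, has not yet been measured. It differs from compound 3 by chloro in place of hydrogen on an aromatic carbon. This is the same kind of change as that from compound 1 to compound 2, but not the same: in compound 2 the chloro sits on a ring with one nitrogen, two atoms from the ring nitrogen and para to a large group, whereas in compound 4 it sits on a ring of carbon only, ortho to a large group.

Because compound 3 is "not active" (no number reported) and the earlier chloro step was a number 10.9 percentage points higher from compound 1 to compound 2 (beyond the scatter), only a modest rise at most is expected, and compound 4 is estimated to give about 12% in this assay, expected to fall between 0% and 35%.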

Compound 4, percent growth inhibition at one concentration: "not active" (no number reported)
For compound 4 the study gives words and no number; the estimate stays without a comparison.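

In this assay, among these compounds, compound 3 gives "not active" (no number reported) and compound 4 gives "not active" (no number reported) so no step between these two compounds can be read. They leave open whether chloro in place of hydrogen on an aromatic carbon changes growth inhibition at all on the core of compound 3. No supporting data shown here bear on this result.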